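The compounds below may be only part of what the source reports. "The series", "measured", "known", "first", "only" and "open" are said of these compounds alone.

Compound 1 `O=[N+]([O-])c1cc(-c2nnc(SCc3ccccc3)n2Cc2ccccc2)cc([N+](=O)[O-])c1` in an ADME assay on A-431 cells (Homo sapiens) for cytotoxicity, with a stated time of 48 h (on this read-out lower numbers stand for stronger inhibition and higher numbers for weaker inhibition), gives only the assay limit > 30000 nM. Compound 2 `COc1ccc(CSc2nnc(-c3cc([N+](=O)[O-])cc([N+](=O)[O-])c3)n2C)cc1` in this assay gives only the assay limit > 30000 nM. Compound 3 `Cn1c(SCc2ccc(Cl)c(Cl)c2)nnc1-c1cc([N+](=O)[O-])cc([N+](=O)[O-])c1` in this assay gives only the assay limit > 30000 nM.

Compound 2 thus stands at a limit and not at a number, and the step that the two limits leave unreadable from compound 2 to compound 3 cannot be read. Compound 4 `COc1ccc(CSc2nnc(-c3cc([N+](=O)[O-])cc([N+](=O)[O-])c3)n2Cc2ccccc2)cc1` differs from compound 2 by phenyl in place of hydrogen on a saturated chain carbon bound to an aromatic nitrogen. Within the data shown here, no measured step changes this position directly; the only single-change step known, a step that the two limits leave unreadable from compound 2 to compound 3, concerns the group on the sulfur side and is itself unreadable. Compound 1 carries the same benzyl group on the aromatic nitrogen and sits at the limit like the others, so every value seen here rests at the limit of > 30000 nM in this assay, at which 3 of the 3 values shown sit, and nothing in the series points to a move away from it.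

Compound 4 is therefore expected to stay at the limit as well, with an estimate of 50000 nM (range 15000 nM to 200000 nM). The step from compound 2 to compound 4 is expected to be a step that the limit leaves unreadable from compound 2 to compound 4, that is, no readable change.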

Compound 4, half-maximal inhibitory concentration: > 30000 nM
Compound 4 ended at the assay's limit; the forecaster's own chance of this, stated with the estimate: 85%; the middle value lies beyond the limit too.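

No new step can be read: compound 1, compound 2 and compound 4 all stand at a limit in this assay, so the changes joining compound 4 to the other two stay unreadable. The compounds shown leave open whether any change to the series gives a numerical value: the limit of > 30000 nM in this assay, at which 4 of the 4 values shown sit.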